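The compounds below may be only part of what the source reports. "The series", "measured", "known", "first", "only" and "open" are said of these compounds alone.

Compound 3 `CC(=O)Nc1cccc(Oc2nc(NCC3CCOCC3)n3ncc(-c4ccc(C(=O)NC5CC5)c(C)c4)c3n2)c1` was tested in a functional assay on MDA-MB-231 cells (Homo sapiens) for antiproliferative activity (on this read-out higher numbers stand for weaker inhibition of growth and lower numbers for stronger inhibition of growth), where compound 3 gives 1600 nM. Compound 2 `O=C(NC1CC1)c1ccc(-c2cnn3c(NCC4CCOCC4)nc(Oc4ccccc4)nc23)cc1` carries a plain phenoxy group in the place where compound 3 carries its 3-acetamidophenoxy group, and its benzamide ring lacks the methyl; in this assay compound 2 gives 350 nM. Of the two numbers that exist, compound 3 has the higher one, and the gap between compound 2 and compound 3 lies beyond the scatter. Compound 1 `CC(C)NC(=O)c1ccc(-c2cnn3c(NCC4CCOCC4)nc(OC4CCCC4)nc23)cc1` has no number in this assay, where compound 1 is recorded as "not determined" (no result reported).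

Compound 4 `Cc1cc(-c2cnn3c(NCC4CCOCC4)nc(Nc4cccc(F)c4)nc23)ccc1C(=O)NC1CC1` differs from compound 3 in one place: (3-fluorophenyl)amino in place of 3-acetamidophenoxy on an aromatic carbon. Within the data shown here, no pair of measured compounds isolates this change. Compound 2, with its plain phenoxy group, gives 350 nM, which hints that a different aryl group in this place can go with a lower number. For compound 4 a moderate downward step is therefore expected, a 2.7-fold lower number from compound 3 to compound 4 (0.43 log units; beyond the scatter), toward stronger inhibition of growth. The estimate for compound 4 in this assay is 600 nM, with a plausible range from 150 nM to 2000 nM.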

Compound 4, concentration for 50% growth inhibition: 16 nM
Compound 4: the middle estimate sits 38-fold (1.57 log units) above what was measured; measured number outside the range, below it.
By their numbers in this assay, from the lowest: compound 4; then compound 2; then compound 3.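

In this assay, among these compounds, the group on this aromatic carbon, between two ring nitrogen atoms, matters far more than the earlier compounds could reveal: exchanging 3-acetamidophenoxy for (3-fluorophenyl)amino gives a 100-fold lower number from compound 3 to compound 4 (2.00 log units; beyond the scatter) and this counts as a large step. The rest of the two molecules is identical, so this one place alone accounts for the whole difference. No measurement at hand explains why the exchange has so strong an effect.

Going by these compounds, the exchange alters both the atom linking the ring to the core and the group carried on that ring, so the share of each stays open. A 3-fluorophenoxy group or a (3-acetamidophenyl)amino group in this place would separate the two contributions.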